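The compounds below may be only part of what the source reports. "The series", "measured", "known", "first", "only" and "open" are said of these compounds alone.

Compound 1 `O=S(=O)(c1ccccc1)c1nc2ccccc2nc1N1CCCC1`: in a functional assay on A549 cells (Homo sapiens) for cytotoxicity, read by MTT assay, with a stated time of 72 h (on this read-out lower numbers stand for stronger inhibition and higher numbers for weaker inhibition), compound 1 gives 34800 nM.
Compound 2 `Cc1ccc(S(=O)(=O)c2nc3ccccc3nc2N2CCCC2)cc1`: in this assay compound 2 reaches only a limit of the assay, > 50000 nM.
Compound 3 `O=S(=O)(c1ccccc1)c1nc2ccccc2nc1N1CCC(O)CC1`: in this assay compound 3 gives 2060 nM.

The change from compound 1 to compound 2, (methyl in place of hydrogen on an aromatic carbon), gave an at least 1.4-fold higher number from compound 1 to compound 2 (0.15 log units; that floor lies within the scatter); the value of compound 2 is a limit, (the limit of > 50000 nM in this assay, at which 1 of the 3 values shown sits), so the true size of that step is not fixed. The cores of compound 1 and compound 3 differ by 4-hydroxypiperidin-1-yl in place of pyrrolidin-1-yl on an aromatic carbon, which gave a 17-fold lower number from compound 1 to compound 3 (1.23 log units; beyond the scatter). Compound 4 `Cc1ccc(S(=O)(=O)c2nc3ccccc3nc2N2CCC(O)CC2)cc1` carries the same change on the core of compound 3: methyl in place of hydrogen on an aromatic carbon. The expected step is a 1.7-fold higher number from compound 3 to compound 4 (0.23 log units; within the scatter), a modest rise in number, resting on an at least 1.4-fold higher number from compound 1 to compound 2 (0.15 log units; that floor lies within the scatter) and on (the limit of > 50000 nM in this assay, at which 1 of the 3 values shown sits), which leave the size open. Compound 4 is estimated at 3500 nM, between 1500 nM and 9000 nM.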

Compound 4, half-maximal inhibitory concentration: 4020 nM
Estimate against measurement, compound 4: 1.1-fold (0.06 log units) below, and the stated range covers the measured number.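

In this assay, the methyl change on the core of compound 3 gives a 2.0-fold higher number from compound 3 to compound 4 (0.29 log units; within the scatter), and the same change on the core of compound 1 can be set against it only as a floor: the same change on two cores in this assay, an at least 1.4-fold higher number (0.15 log units; that floor lies within the scatter) from compound 1 to compound 2 and a 2.0-fold higher number (0.29 log units; within the scatter) from compound 3 to compound 4; the limit leaves it open whether they differ. The change from pyrrolidin-1-yl to 4-hydroxypiperidin-1-yl again gives a large step, an at least 12-fold lower number from compound 2 to compound 4 (1.09 log units; beyond the scatter), in the same direction as on the phenyl compounds: the same change on two cores in this assay, a 17-fold lower number (1.23 log units; beyond the scatter) from compound 1 to compound 3 and an at least 12-fold lower number (1.09 log units; beyond the scatter) from compound 2 to compound 4; the limit leaves it open whether they differ. The value of compound 2 is a limit, so the pairs show that the direction of this step carries over, not that its size does.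

Open, from the compounds shown here alone, is whether a larger group than methyl, such as a chlorine atom or methoxy, on the phenyl ring would leave the number unmoved. Also open, going by these compounds, is whether an amine or a carboxylic acid in place of the hydroxy group of 4-hydroxypiperidin-1-yl would keep the lower number.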